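Swapping Phenyl for 2-Chlorophenoxy on an Acylguanidine Core

This account rests on a few compounds, and the source may have more. Where it says the series, first, only, none or still open, it means among the compounds named here.

The measured compounds, in a functional assay for inhibition of sodium/hydrogen exchanger (Oryctolagus cuniculus); a higher number here means a weaker inhibitor, a lower number a stronger inhibitor:
- compound 1 `CCN(CC)Cc1cc(Br)c(S(C)(=O)=O)cc1C(=O)N=C(N)N` gives 9500 nM
- compound 2 `Cc1cc(-c2ccccc2)c(S(C)(=O)=O)cc1C(=O)N=C(N)N` gives 19 nM

Compound 2 stands at the lowest number of the two, and the gap between compound 2 and compound 1 is far beyond the scatter, so compound 2 is clearly the stronger inhibitor of the pair. Compound 3 `Cc1cc(Oc2ccccc2Cl)c(S(C)(=O)=O)cc1C(=O)N=C(N)N` has not yet been measured. It differs from compound 2 in one place: 2-chlorophenoxy in place of phenyl on an aromatic carbon. Among the measured compounds shown here, no pair of measured compounds shows a step of this kind, so there is no precedent here for how such a change moves the number.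

For compound 3 the estimated value in this assay is 45 nM, with a range from 10 nM to 250 nM. This estimate means a step of a 2.4-fold higher number from compound 2 to compound 3 (0.37 log units; beyond the scatter), expected to be modest, toward a weaker inhibitor, and possibly not beyond the scatter.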

Compound 3, half-maximal inhibitory concentration: 14 nM
Estimate against measurement, compound 3: 3.2-fold (0.51 log units) above; measured number inside the range.
By their numbers in this assay, from the lowest: compounds 3 and 2 (each within the scatter of the next); then compound 1.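

In this assay the change to 2-chlorophenoxy in place of phenyl gives a 1.4-fold lower number from compound 2 to compound 3 (0.13 log units; within the scatter) and so leaves the number where it was. This position, ortho to a methylsulfonyl group, therefore holds either group with no difference that this read-out can separate, even though the entering group has 8 heavy atoms against 6 and brings a hydrogen-bond acceptor that phenyl lacks. No supporting measurement bears on why the two groups read alike.

The compounds shown leave open what the oxygen and the chlorine each contribute, a question that plain phenoxy or 2-chlorophenyl at this position would help to settle. They also leave open how this position would respond to a quite different group, such as an amine or a carboxylic acid.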